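Swapping the aryl end of the amide side chain

The source may hold more compounds than are shown below. What is called first, only, known or untested is meant among the compounds shown, and "the series" means these compounds.

Compound 1 `O=C(CCc1ccccc1)Nc1nc2ccccc2c(=O)s1`: 422 nM
Compound 2 `O=C(CCc1ccccc1Br)Nc1nc2ccccc2c(=O)s1`: > 10000 nM

In an assay on membranes from brain for displacement of a labelled ligand from adenosine receptor A1 (Rattus norvegicus), read by scintillation counting, with a stated time of 90 min (a higher number here means a weaker inhibitor, a lower number a stronger inhibitor), compound 1 gives 422 nM. For compound 2 the result is only a limit, > 10000 nM. That limit is the one described as the limit of > 10000 nM in this assay, at which 1 of the 2 values shown sits. Among the measured compounds shown here, the single measured step, an at least 23-fold higher number from compound 1 to compound 2 (1.37 log units; beyond the scatter), is the only guide available: adding bromine on the aromatic carbon pushed the number past the limit of this assay. Compound 3 `O=C(CCCc1cccc(Cl)c1)Nc1nc2ccccc2c(=O)s1` differs from compound 2 by 3-chlorobenzyl in place of 2-bromophenyl on a saturated chain carbon, two bonds along the chain from a carbonyl carbon. For the measured compounds named here, both the bromine and the chain length change at once, and no measured compound carries a 3-chlorobenzyl group or this longer chain, so the measured step does not transfer directly. Because compound 1 gives 422 nM with the plain chain, the number for compound 3 is expected to come back down, a step of an at least 4.0-fold lower number from compound 2 to compound 3 (0.60 log units; beyond the scatter), though with wide uncertainty. Compound 3 is therefore estimated at 2500 nM, within 500 nM to 12000 nM.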

Compound 3, inhibition constant: 898 nM
Beside the measured number, compound 3's estimate is 2.8-fold (0.44 log units) above it; low and high end bracket the measured number.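

In this assay, the swap to 3-chlorobenzyl at this place on the chain brings back a measurable number, an at least 11-fold lower number from compound 2 to compound 3 (1.04 log units; beyond the scatter), so a halogen-bearing aryl end is not in itself incompatible with binding here. The value for compound 2 is only a limit: the limit of > 10000 nM in this assay, at which 1 of the 3 values shown sits. Against the unsubstituted phenyl, the same swap costs only a modest step, a 2.1-fold higher number from compound 1 to compound 3 (0.33 log units; beyond the scatter), which shows that this place accepts a larger, chlorine-bearing group with far less loss than the 2-bromophenyl group produced.

The 3-chlorobenzyl group differs from 2-bromophenyl in both its halogen and its carbon count, and these compounds do not separate the two changes. Going by these compounds, how an unsubstituted benzyl group, a methoxy group or an amine on the aryl end would read at this place remains open.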